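The source may report more compounds than this note shows. Statements on the series, on what has been measured and on what is new or still open speak of the compounds shown alone.

Measured so far in a functional assay (Cavia porcellus) with sulfonylurea receptors; K-ATP channels (Homo sapiens) as the target; on this read-out lower numbers stand for stronger inhibition and higher numbers for weaker inhibition:
compound 1, `CC(O)(C(=O)Nc1ccc(S(=O)(=O)c2ccccc2C#N)cc1)C(F)(F)F`: 1100 nM
compound 2, `CC(O)(C(=O)Nc1ccc(S(=O)(=O)c2ccccc2O)cc1)C(F)(F)F`: 3090 nM
compound 3, `CC(O)(C(=O)Nc1ccc(C(=O)c2ccccc2)cc1C#N)C(F)(F)F`: 3800 nM

Compound 1 and compound 2 differ in one place, (hydroxy in place of cyano on an aromatic carbon), and that single change gave a 2.8-fold higher number from compound 1 to compound 2 (0.45 log units; beyond the scatter). Compound 3 rests on another core; the difference between its core and that of compound 1 is not broken down here. Compound 3 and compound 2 lie within the scatter of each other, while compound 3 against compound 1 lies beyond it.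

Compound 4, `CC(O)(C(=O)Nc1ccc(C(=O)c2ccccc2)cc1O)C(F)(F)F`, has not yet been run in this assay. It comes from compound 3 by hydroxy in place of cyano on an aromatic carbon. Among the measured compounds shown here, this is the same kind of change as the one from compound 1 to compound 2, not the same: here the place is also meta to a benzoyl group (8 heavy atoms), which the earlier place lacks. For the measured compounds named here, the expectation rests on the one precedent, a 2.8-fold higher number from compound 1 to compound 2 (0.45 log units; beyond the scatter), carried onto a core whose relation to the first is not broken down, so a step of similar direction and size is expected, a 2.4-fold higher number from compound 3 to compound 4 (0.37 log units; beyond the scatter). Compound 4 is therefore estimated at 9000 nM in this assay, expected to fall between 3500 nM and 23000 nM.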

Compound 4, half-maximal inhibitory concentration: 15000 nM
Compound 4: middle estimate off by 1.7-fold (0.22 log units), on the low side; measured number inside the range.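

Replacing cyano with hydroxy on an aromatic carbon gave, in this assay, a 3.9-fold higher number from compound 3 to compound 4 (0.60 log units; beyond the scatter), so the number rose on this core as it did on the core of compound 1. Set side by side, the two steps cannot be told apart: the same change on two cores in this assay, a 2.8-fold higher number (0.45 log units; beyond the scatter) from compound 1 to compound 2 and a 3.9-fold higher number (0.60 log units; beyond the scatter) from compound 3 to compound 4, 1.4-fold (0.15 log units) apart, within the scatter of two such steps. Across these two pairs the change carried over in direction and size, even though the place in compound 4 is meta to a benzoyl group, but two pairs do not make a rule for the series and do not show why the number rises.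

The compounds shown leave open whether other groups in these places, such as an amine, a carboxylic acid or a methoxy group, would fall closer to cyano or to hydroxy. They also leave open whether the step would hold on cores other than those of compound 1 and compound 3.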